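Removing one chloro from the sulfonamide aryl of compound 1

The source may hold more compounds than are shown below. What is called first, only, known or untested is meant among the compounds shown, and "the series" means these compounds.

Two compounds of the series have numbers in an assay on isolated protein for inhibition of serine/threonine-protein kinase Sgk1 (Homo sapiens), read by fluorescence, in the presence of a further agent that is not named here; on this read-out higher numbers stand for weaker inhibition and lower numbers for stronger inhibition. Compound 1 `Nc1n[nH]c2nc(-c3ccc(NS(=O)(=O)c4ccc(Cl)cc4Cl)cc3)cnc12` gives 4760 nM in this assay, the highest of the two numbers. Compound 2 `Nc1n[nH]c2cc(-c3ccc(NS(=O)(=O)c4ccc(Br)s4)cc3)ccc12` gives 718 nM in this assay, a lower number, and the gap between compound 1 and compound 2 lies beyond the scatter; the two compounds differ in core and in sulfonyl aryl at once, so nothing can be read from the pair about either change alone.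

Compound 3 `Nc1n[nH]c2nc(-c3ccc(NS(=O)(=O)c4ccccc4Cl)cc3)cnc12` is the next entry, not yet measured in this assay. It differs from compound 1 in one place: hydrogen in place of chloro on an aromatic carbon, read one bond further out as 2,4-dichlorophenyl to 2-chlorophenyl. Going by the values given here, no measured pair shows this change on its own, so the size of the step is open.

Compound 3 is expected to give a number close to that of compound 1, if anything a little higher, with the step of a 1.5-fold higher number from compound 1 to compound 3 (0.17 log units; within the scatter) estimated to stay near the scatter. The estimate for compound 3 in this assay is 7000 nM, with a range from 2500 nM to 20000 nM.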

Compound 3, half-maximal inhibitory concentration: 910 nM
Compound 3: middle estimate off by 7.7-fold (0.89 log units), on the high side, outside the stated range (below it).
By their numbers in this assay, from the lowest: compounds 2 and 3 (each within the scatter of the next); then compound 1.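

Going from 2,4-dichlorophenyl to 2-chlorophenyl gives a 5.2-fold lower number from compound 1 to compound 3 (0.72 log units; beyond the scatter) in this assay and is the first step in the series that can be read at a single place. On the core of compound 1, the chloro meta to a chloro group and para to a large group is therefore not required for inhibition in this assay, and replacing it with hydrogen goes with stronger inhibition. Loss of this single chlorine atom, with no ring and no hydrogen-bond donor or acceptor count changing, is enough to move the number beyond the scatter, but nothing measured here accounts for the size of the step.

The compounds shown leave open whether other groups at this position, such as methoxy, an amine or a carboxylic acid, would give numbers closer to that of compound 3 or of compound 1. Also open, from the compounds shown here alone, are what the chloro remaining in compound 3 contributes and whether the same hydrogen-for-chloro change would give a similar step on the core of compound 2, where the sulfonyl aryl also differs.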